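Methoxy for bromo on two related chalcone cores

This account rests on a few compounds, and the source may have more. Where it says the series, first, only, none or still open, it means among the compounds named here.

The series comprises four compounds built on two closely related cores. Compound 1 `O=C(/C=C/c1csc2ccccc12)c1cc(Br)ccc1O` carries a bromo substituent, and compound 2 `COc1ccc(O)c(C(=O)/C=C/c2csc3ccccc23)c1` differs from it by methoxy in place of bromo on an aromatic carbon. Compound 3 `O=C(/C=C/c1cc2ccccc2s1)c1cc(Br)ccc1O` is made of the same atoms as compound 1, joined differently; the difference between the two cores is not broken down here. Compound 4 `COc1ccc(O)c(C(=O)/C=C/c2cc3ccccc3s2)c1` is the counterpart of compound 3 and differs from it by methoxy in place of bromo on an aromatic carbon, so the change from compound 3 to compound 4 is the same change as that from compound 1 to compound 2.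

In a functional assay on MDA-MB-231 cells (Homo sapiens) for antiproliferative activity, read by sulforhodamine B assay, with a stated time of 72 h (a higher number here means a weaker inhibitor, a lower number a stronger inhibitor), compound 1 gives 840 nM. In this assay compound 2 gives 760 nM, a step of a 1.1-fold lower number from compound 1 to compound 2 (0.04 log units; within the scatter). In this assay compound 3 gives only a limit, > 10000 nM. Compound 3 thus sits at the limit of > 10000 nM in this assay, at which 1 of the 3 values shown sits.

For compound 4 the same exchange is expected to move the number little, because on the core of compound 1 it gave a 1.1-fold lower number from compound 1 to compound 2 (0.04 log units; within the scatter). The step from compound 3 to compound 4 in this assay is therefore estimated at a step that the limit leaves unreadable from compound 3 to compound 4. Compound 4 is expected to give 15000 nM. The estimate for compound 4 is expected to fall between 6000 nM and 40000 nM, and there is a good chance that compound 4 will likewise be reported only as a limit.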

Compound 4, half-maximal inhibitory concentration: > 10000 nM
Compound 4: a limit, no number (the forecaster's own chance of this, stated with the estimate: 70%); the middle value is on the limit's open side.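

In this assay compound 4 gives > 10000 nM as a limit and not a number. For the compounds shown here, compound 3 stands at the same limit, so no step from compound 3 to compound 4 can be read: the limit of > 10000 nM in this assay, at which 2 of the 4 values shown sit. The compounds shown leave open whether methoxy in place of bromo moves the number as little on the core of compound 3 as on the core of compound 1.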